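This account rests on a few compounds, and the source may have more. Where it says the series, first, only, none or still open, it means among the compounds named here.

In a functional assay on K562 cells (Homo sapiens) for antiproliferative activity, with a stated time of 72 h (on this read-out higher numbers stand for weaker inhibition and lower numbers for stronger inhibition), compound 3 `Cc1ccc(CNc2ncnc3c2ncn3[C@@H]2O[C@H](CO)[C@@H](O)[C@H]2O)cc1` gives only a limit, > 166000 nM, and no number. Compound 1 `OC[C@H]1O[C@@H](n2cnc3c(NCc4cccc(F)c4)ncnc32)[C@H](O)[C@@H]1O` reads 7600 nM and compound 2 `OC[C@H]1O[C@@H](n2cnc3c(NCc4ccccc4Cl)ncnc32)[C@H](O)[C@@H]1O` reads 64000 nM, which leaves compound 3 at the weak end of the three.

The next change leads to compound 4 `COc1cccc(CNc2ncnc3c2ncn3[C@@H]2O[C@H](CO)[C@@H](O)[C@H]2O)c1OC`: 2,3-dimethoxyphenyl in place of 4-methylphenyl on a saturated chain carbon bound to a nitrogen on an aromatic ring.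

Three measured steps at this same place bear on it: an 8.4-fold higher number from compound 1 to compound 2 (0.93 log units; beyond the scatter), an at least 21-fold higher number from compound 1 to compound 3 (1.33 log units; beyond the scatter) and an at least 2.5-fold higher number from compound 2 to compound 3 (0.41 log units; beyond the scatter). All three lie beyond the scatter, and both steps that end at compound 3 run towards higher numbers. Since 4-methylphenyl is the group leaving, a move the other way is expected, and the smaller of those two steps, an at least 2.5-fold higher number from compound 2 to compound 3 (0.41 log units; beyond the scatter), suggests a modest size. Going by the values given here, no measured compound carries a dimethoxyphenyl group, so the range stays wide and a second limit remains possible.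

The expected change in this assay is an at least 3.3-fold lower number from compound 3 to compound 4 (0.52 log units; beyond the scatter). For compound 4 the estimate is 50000 nM, with an expected range of 12000 nM to 166000 nM.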

Compound 4, half-maximal inhibitory concentration: > 166000 nM
Compound 4: only a limit was reported; the forecaster's own chance of this, stated with the estimate: 35%; middle value at least 3.3-fold (0.52 log units) from the limit.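

In this assay compound 4 gives only a limit and no number, the same limit as compound 3: the limit of > 166000 nM in this assay, at which 2 of the 4 values shown sit. The two limits leave the step between compound 3 and compound 4 unreadable, so adding two methoxy groups and losing the methyl group gives no readable gain or loss here. Against the other compounds the change reads as an at least 2.5-fold higher number from compound 2 to compound 4 (0.41 log units; beyond the scatter) and an at least 21-fold higher number from compound 1 to compound 4 (1.33 log units; beyond the scatter), which places 2,3-dimethoxyphenyl with 4-methylphenyl at the weak end and leaves 3-fluorophenyl with the lowest number of the four.

No order between 4-methylphenyl and 2,3-dimethoxyphenyl can be drawn from these compounds. As far as these compounds go, whether an amine or a carboxylic acid on the phenyl ring, or a longer chain in place of the saturated chain carbon, would bring a number under the limit stays open.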